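Clearance along the ring-nitrogen substituent series

The compounds below may be only part of what the source reports. "The series", "measured", "known", "first", "only" and "open" are said of these compounds alone.

Compound 1 `CC(C)n1cc(-c2ccnc3[nH]c(C4CCNCC4)cc23)ccc1=O` carries hydrogen on an amine nitrogen in a ring. In an ADME assay on microsomes from liver (Homo sapiens) for metabolic stability (a lower number here means slower removal, a higher number faster removal of the compound), compound 1 gives < 3 uL/min, which is a limit of the assay and not a number. Compound 2 `CC(C)n1cc(-c2ccnc3[nH]c(C4CCN(CC(=O)N5CCCC5)CC4)cc23)ccc1=O` bears ((pyrrolidin-1-yl)carbonyl)methyl at that nitrogen, and in this assay compound 2 gives 45 uL/min. The step of an at least 15-fold higher number from compound 1 to compound 2 (1.17 log units; beyond the scatter) is the only measured step in the series; the value of compound 2 is the single number shown, the other value being a limit (the limit of < 3 uL/min in this assay, at which 1 of the 2 values shown sits). Compound 3 `CC(C)n1cc(-c2ccnc3[nH]c(C4CCN(Cc5cccs5)CC4)cc23)ccc1=O` is the next member: thiophen-2-yl in place of (pyrrolidin-1-yl)carbonyl on a saturated chain carbon bound to an amine nitrogen in a ring. No measured step tracks this exchange directly; the one known step, an at least 15-fold higher number from compound 1 to compound 2 (1.17 log units; beyond the scatter), covers only the attachment of the whole chain to a bare nitrogen, whereas compound 2 already carries a chain at that position, so the shown data give no direction for the swap of the terminal group. The expectation for compound 3 in this assay is therefore a step of a 1.1-fold higher number from compound 2 to compound 3 (0.05 log units; within the scatter) that stays within the scatter, with wide uncertainty. Compound 3 is estimated at 50 uL/min, with a range from 20 uL/min to 130 uL/min.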

Compound 3, intrinsic clearance in a liver preparation (reported as CLH), per the amount of preparation that the assay uses: 84 uL/min
Compound 3: middle estimate off by 1.7-fold (0.23 log units), on the low side; the measured number falls inside the stated range.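

In this assay, exchanging (pyrrolidin-1-yl)carbonyl for thiophen-2-yl on a saturated chain carbon bound to an amine nitrogen in a ring gives a 1.9-fold higher number from compound 2 to compound 3 (0.27 log units; within the scatter), so this read-out does not separate the two terminal groups, despite their different ring types and the amide carbonyl present only in the first. The large step seen on substituting the bare nitrogen now appears with a second chain, an at least 28-fold higher number from compound 1 to compound 3 (1.44 log units; beyond the scatter), so across the compounds shown, both substituents at this nitrogen stand well apart from hydrogen. The value of compound 1 remains a limit of the assay and not a number: the limit of < 3 uL/min in this assay, at which 1 of the 3 values shown sits.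

The compounds shown do not tell whether a small group at this nitrogen, such as plain methyl, stays close to hydrogen or already joins compound 2 and compound 3. Going by these compounds, it also remains open how this assay responds to a carboxylic acid in place of thiophen-2-yl, or to a longer chain carrying either terminal group.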